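This account rests on a few compounds, and the source may have more. Where it says the series, first, only, none or still open, it means among the compounds named here.

Measured so far:

Compound 1, `Nc1cccc2c(-c3cccc(NC(=O)c4ccc5c(c4)OCCO5)c3)ccnc12`, gives 30 nM in a functional assay on MDA-MB-435 cells (Homo sapiens) for antiproliferative activity, read by sulforhodamine B assay, with a stated time of 48 h; a lower number here means a stronger inhibitor, a higher number a weaker inhibitor.

Compound 2, `CC(=O)Nc1cccc2c(-c3cccc(NC(=O)c4ccc(Cl)c(C(F)(F)F)c4)c3)ccnc12`, gives 2700 nM in this assay.

Compound 2 holds the highest of the two numbers, so of the two it is the weaker inhibitor; the two compounds differ in two places, and the gap between their values is well beyond the usual scatter. The unmeasured compound 3, `CC(=O)Nc1cccc2c(-c3cccc(NC(=O)c4ccc5c(c4)OCCO5)c3)ccnc12`, keeps the acetylated core of compound 2 and changes only the amide: 2,3-dihydro-1,4-benzodioxin-6-yl in place of 4-chloro-3-(trifluoromethyl)phenyl on a carbonyl carbon. This puts on compound 2 the same amide that compound 1 carries, while the acetamide of compound 2 stays. With no single-change comparison to lean on, the expectation is a clear move towards a lower number, estimated as a 9.0-fold lower number from compound 2 to compound 3 (0.95 log units; beyond the scatter). Compound 3 is expected to give about 300 nM, with a plausible range from 50 nM to 2000 nM.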

Compound 3, half-maximal inhibitory concentration: 27 nM
The estimate for compound 3 lay 11-fold (1.05 log units) above the measured number, outside the stated range (below it).
By their numbers in this assay, from the lowest: compounds 3 and 1 (each within the scatter of the next); then compound 2.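

In this assay, with the acetylated core held fixed, changing the group on the carbonyl carbon from 4-chloro-3-(trifluoromethyl)phenyl to 2,3-dihydro-1,4-benzodioxin-6-yl gives a 100-fold lower number from compound 2 to compound 3 (2.00 log units; beyond the scatter) and so counts as a large step at this position. Acetyl in place of hydrogen on the nitrogen on the aromatic ring gives a 1.1-fold lower number from compound 1 to compound 3 (0.05 log units; within the scatter) and shows that, with 2,3-dihydro-1,4-benzodioxin-6-yl on the carbonyl carbon, this nitrogen can carry either group with no difference beyond the scatter. Nothing on hand explains the size of the amide step.

Still open, going by these compounds, is whether hydrogen in place of acetyl would matter with 4-chloro-3-(trifluoromethyl)phenyl on the carbonyl carbon, and whether the chlorine or the trifluoromethyl goes with the higher number. Also open, on these data alone, is how a longer acyl chain on the nitrogen, or a plain phenyl on the carbonyl carbon, would read.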